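The source may hold more compounds than are shown below. What is called first, only, known or untested is meant among the compounds shown, and "the series" means these compounds.

Working notes on the series, read in an ADME assay on Vero cells (Chlorocebus sabaeus) for cytotoxicity, read by MTT assay; a higher number here means that more compound is tolerated, a lower number that less compound is tolerated. Compound 1 `COc1ccc(-c2nc3ccccn3c2Nc2cc(OC)c(OC)c(OC)c2)cc1O` gives 50000 nM, compound 2 `COc1ccc(-c2nc3cnccn3c2Nc2cc(OC)c(OC)c(OC)c2)cc1O` gives 50000 nM, and compound 3 `COc1ccc(-c2nc3cnccn3c2Nc2cc(OC)c(OC)c(OC)c2)cc1` gives 75000 nM, which places compound 3 within the scatter of both others. Next comes compound 4 `COc1cc(Nc2c(-c3cccc(O)c3)nc3cnccn23)cc(OC)c1OC`, with this change: 3-hydroxyphenyl in place of 4-methoxyphenyl on an aromatic carbon. In words, 3-hydroxyphenyl stands in place of 4-methoxyphenyl on an aromatic carbon. Among the compounds with values here, only one measured step bears on this change, a 1.5-fold higher number from compound 2 to compound 3 (0.18 log units; within the scatter), hydrogen in place of hydroxy on an aromatic carbon. Within the data shown here, the data hold no measured step that removes a methoxy group. No step beyond the scatter is therefore expected in this assay. The estimated step is a 1.4-fold lower number from compound 3 to compound 4 (0.13 log units; within the scatter). For compound 4 the expected value is 55000 nM, with an estimated range of 28000 nM to 100000 nM.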

Compound 4, concentration lethal to 50% of the cells: 63000 nM
The estimate for compound 4 lay 1.1-fold (0.06 log units) below the measured number, and the stated range covers the measured number.
By their numbers in this assay, from the lowest: compounds 1, 2, 4 and 3 (each within the scatter of the next).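

In this assay, within the data shown here, the aromatic carbon of the five-membered ring tolerates a swap of the whole aryl group: 3-hydroxyphenyl in place of 4-methoxyphenyl gives a 1.2-fold lower number from compound 3 to compound 4 (0.08 log units; within the scatter) and so stays level with the earlier compounds. A step removing a methoxy group, absent until now, appears as hydrogen in place of methoxy and gives a 1.3-fold higher number from compound 2 to compound 4 (0.10 log units; within the scatter) for the same aryl group. No measurement here offers a reason for either step.

Going by these compounds, an amine, a carboxylic acid or a longer chain on this phenyl ring remains open, as does whether any group at this place gives a step beyond the scatter.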